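From amino to ureido, compound 3 to compound 4

A few compounds are considered here, and "the series" means these few. Any claim that something is new, unique, unknown or untested is made for them only; others in the source may bear on it.

Compound 1 `NCCCCN(C[C@H]1Cc2cccnc2CN1)[C@H]1CCCc2cccnc21` gives 6 nm/s
Compound 2 `NCCCCN(C[C@@H]1Cc2cccnc2CN1)[C@H]1CCCc2cccnc21` gives 77 nm/s
Compound 3 `NC/C=C/CN(C[C@H]1Cc2ncccc2CN1)[C@H]1CCCc2cccnc21` gives 15 nm/s

These three numbers all come from an ADME assay for permeability, using PAMPA, with a stated time of 4 h, at pH 7.4; on this read-out higher numbers stand for higher permeability and lower numbers for lower permeability. Compound 3 stands second highest of the three, above compound 1 and below compound 2. Compound 4 `NC(=O)NC/C=C/CN(C[C@H]1Cc2ncccc2CN1)[C@H]1CCCc2cccnc21` has yet to be measured in this assay. It differs from compound 3 by carbamoyl in place of hydrogen on an amine nitrogen, so that aminomethyl becomes ureidomethyl.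

Going by the values given here, only one measured step exists, a 13-fold higher number from compound 1 to compound 2 (1.11 log units; beyond the scatter). It is large, but it concerns configuration alone the fact that compounds 1 and 2 differ only in the configuration as drawn and leaves that amine nitrogen untouched. It therefore gives no direction for the present change and shows only how far these numbers can move, which argues for a wide range. With compound 3 at 15 nm/s, well under the highest number, a modest rise is expected rather than a fall. The expected change is a 2.3-fold higher number from compound 3 to compound 4 (0.37 log units; beyond the scatter). For compound 4 the estimated value is 35 nm/s, with an expected range from 10 nm/s to 120 nm/s.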

Compound 4, apparent permeability: 2 nm/s
Compound 4: middle estimate off by 18-fold (1.24 log units), on the high side, and the stated range ends above it.
By their numbers in this assay, from the lowest: compound 4; then compound 1; then compound 3; then compound 2.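

In this assay, carbamoyl in place of hydrogen on this amine nitrogen gives a 7.5-fold lower number from compound 3 to compound 4 (0.88 log units; beyond the scatter) and so marks this nitrogen as a place where the number responds to substitution. The only earlier step concerned configuration alone, so this is the first direction shown for a change at this nitrogen, and on compound 3 the change from amino to ureido lowers the number. The evidence at hand offers nothing that bears on why the number moves this way at this nitrogen.

The compounds shown leave open whether a smaller acyl group such as acetyl, or a plain methyl on the same nitrogen, would lower the number as carbamoyl does. They also leave open whether carbamoyl would give a step of similar size on compound 1 or compound 2.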